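The source may report more compounds than this note shows. Statements on the series, on what has been measured and on what is new or still open speak of the compounds shown alone.

Measured so far:
compound 1 `Clc1ccc(-c2cn3ccnc3c(-c3ccc4ncn(C5CCCCC5)c4c3)n2)cc1` gives 31.2% in a functional assay on SNB-75 cells (Homo sapiens) for inhibition, read by sulforhodamine B assay, with a stated time of 48 h, tested at 10 uM; a lower number here means less inhibition, a higher number more inhibition at the concentration tested (going by the name of the read-out)
compound 2 `CCc1ccc(-c2cn3ccnc3c(-c3ccc4ncn(Cc5ccccc5)c4c3)n2)cc1` gives 29.3% in this assay

Two compounds of the series carry numbers in this assay. Compound 1 gives 31.2% and compound 2 gives 29.3%; the two values lie within the usual scatter of one another, so the numbers shown give no ordering between them. Among the measured compounds shown here, both compounds share the same core and differ in more than one place, so no single-change step exists within the measured set.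

Compound 3 `c1ccc(Cn2cnc3ccc(-c4nc(-c5cccc6ccccc56)cn5ccnc45)cc32)cc1` is not yet measured. Compared with compound 2 the change is naphthalen-1-yl in place of 4-ethylphenyl on an aromatic carbon. For the measured compounds named here, with no measured step on this core to lean on, the expectation is a step from compound 2 to compound 3 of a number 0.7 percentage points higher from compound 2 to compound 3 (within the scatter), that is no change beyond the scatter. Compound 3 is therefore expected to give about 30%, in a range from 12% to 50%.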

Compound 3, a percentage reported as inhibition, at one concentration (the size of the read-out at that concentration, not a potency): 16.2%
For compound 3 the middle estimate is 13.8 percentage points above the measured one; the measured number falls inside the stated range.
By their numbers in this assay, from the lowest: compound 3; then compounds 2 and 1 (each within the scatter of the next).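

In this assay, this aromatic carbon next to the ring nitrogen now has its first readable single change: naphthalen-1-yl in place of 4-ethylphenyl gives a number 13.1 percentage points lower from compound 2 to compound 3 (beyond the scatter). The readout at this position therefore responds to the choice of aryl group, even though the entering and leaving groups are both carbon-only and neither carries a hydrogen-bond donor, a hydrogen-bond acceptor or a net charge. No measurement at hand bears on the reason for this step.

The compounds shown leave open whether the step is specific to naphthalen-1-yl or would also appear with naphthalen-2-yl, or with a phenyl ring bearing an amine or a carboxylic acid. They also leave open whether the same change would give a similar step with cyclohexyl in place of benzyl on the core.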